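This account rests on a few compounds, and the source may have more. Where it says the series, first, only, none or still open, it means among the compounds named here.

Measured compounds and their results:
Compound 1, `COc1ccc(C(=O)/C=C/c2ccc(F)cc2)c2c1C=CC(C)(C)O2`: > 10000 nM
Compound 2, `COc1ccc(C(=O)/C=C/c2cccc(F)c2)c2c1C=CC(C)(C)O2`: > 10000 nM
Compound 3, `COc1ccc(C(=O)/C=C/c2cccc3ccccc23)c2c1C=CC(C)(C)O2`: > 10000 nM

Each of these three values is a limit of the assay rather than a number. In a functional assay on SW-620 cells (Homo sapiens) for antiproliferative activity, read by MTT assay, with a stated time of 24 h (a lower number here means a stronger inhibitor, a higher number a weaker inhibitor), compound 1 gives > 10000 nM, which is a limit. Compound 2 and compound 3 stand at the same kind of limit, so all three share (the limit of > 10000 nM in this assay, at which 3 of the 3 values shown sit). Within the data shown here, the only measured step among them, a step that the two limits leave unreadable from compound 1 to compound 2, has no readable size: both of its ends are limits.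

Compound 4 is `COc1ccc(C(=O)/C=C/c2ccc(Cl)c(Cl)c2)c2c1C=CC(C)(C)O2`. It differs from compound 1 in one place: 3,4-dichlorophenyl in place of 4-fluorophenyl on a double-bonded chain carbon bound to a double-bonded chain carbon. Among the measured compounds shown here, the one measured step at this same place, a step that the two limits leave unreadable from compound 1 to compound 2, is unreadable, so nothing in this set shows that a change on the phenyl ring moves a compound away from the limit. The step that the limit leaves unreadable from compound 1 to compound 4 is therefore expected to stay within the usual scatter. For compound 4 the estimate in this assay is 15000 nM, within a range from 3000 nM to 60000 nM, with a real chance that only a limit is reported again.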

Compound 4, half-maximal inhibitory concentration: 7700 nM
Compound 4: the middle estimate sits 1.9-fold (0.29 log units) above what was measured; low and high end bracket the measured number.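

Among these compounds, compound 4 is the first compound here to give a real number in this assay (7700 nM). So this position on the chain can carry a group that leaves the limit, something the earlier compounds never showed: the limit of > 10000 nM in this assay, at which 3 of the 4 values shown sit. On these data alone, the change to 3,4-dichlorophenyl gives an at least 1.2-fold lower number from compound 1 to compound 4 (0.11 log units; that floor lies within the scatter) and also an at least 1.2-fold lower number from compound 2 to compound 4 (0.11 log units; that floor lies within the scatter) and, since these are only floors, the true size of either step is unknown and could be small. The step between the two fluorinated compounds cannot be read, so the position's first readable result comes from compound 4 alone.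

As far as these compounds go, it remains open whether both chlorines are needed or one would serve, as in a 4-chlorophenyl group. The effect of an amine or a carboxylic acid on the same phenyl ring is also unknown.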